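Compound 3 against the limit of compound 2

The compounds below may be only part of what the source reports. "The series", "measured", "known", "first", "only" and "open" are said of these compounds alone.

Among the measured compounds shown here, compound 1 `COc1cc(NC(C)CCCNC(=O)Nc2ccc(F)cc2)c2ncccc2c1` gives 24000 nM in a functional assay on MOLT-4 cells (Homo sapiens) for inhibition, read by MTT assay, with a stated time of 72 h (on this read-out higher numbers stand for weaker inhibition and lower numbers for stronger inhibition), as the one numerical value so far.

Compound 2 `COc1cc(NC(C)CCCNC(=O)NNC(=O)Nc2cccc(F)c2)c2ncccc2c1` stands at >= 250000 nM in this assay and this is a limit, not a number.

The change to compound 3 `COc1cc(NC(C)CCCNC(=O)Nc2ccc(O)cc2)c2ncccc2c1` is 4-hydroxyphenyl in place of ((3-fluorophenyl)carbamoyl)amino on an amide-type nitrogen.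

For the measured compounds named here, one measured step bears on this: an at least 10-fold higher number from compound 1 to compound 2 (1.01 log units; beyond the scatter), which ends at the limit of >= 250000 nM in this assay, at which 1 of the 2 values shown sits, and is large. That step brought ((3-fluorophenyl)carbamoyl)amino onto an amide-type nitrogen, and here the group leaves again, so a move back towards compound 1 at 24000 nM is expected.

A large step is therefore expected in this assay, an at least 10-fold lower number from compound 2 to compound 3 (1.00 log units; beyond the scatter), towards stronger inhibition.

The estimate for compound 3 is 25000 nM, with an expected range of 8000 nM to 80000 nM.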

Compound 3, half-maximal inhibitory concentration: 21000 nM
Compound 3: the middle estimate sits 1.2-fold (0.08 log units) above what was measured; the range from low to high includes it.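

In this assay, hydroxy in place of fluoro on the aromatic carbon leaves the two compounds within the scatter of each other: a 1.1-fold lower number from compound 1 to compound 3 (0.06 log units; within the scatter). The large shift at the amide-type nitrogen appears with ((3-fluorophenyl)carbamoyl)amino and is gone with 4-hydroxyphenyl in its place: an at least 11-fold lower number from compound 2 to compound 3 (1.07 log units; beyond the scatter). Compound 2 is held only as a limit, not a number, so this step gives a bound rather than a true size: the limit of >= 250000 nM in this assay, at which 1 of the 3 values shown sits.

The compounds shown do not separate the contribution of the extra carbamoyl-amino unit in compound 2 from that of its 3-fluorophenyl group. Also open, on these data alone, is whether an amine or a carboxylic acid in place of the hydroxy would stay within the scatter of compound 3 at 21000 nM.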